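The source may hold more compounds than are shown below. What is called first, only, known or untested is meant among the compounds shown, and "the series" means these compounds.

Measured in a functional assay on HCT-116 cells (Homo sapiens) for antiproliferative activity, read by MTT assay, with a stated time of 48 h; a lower number here means a stronger inhibitor, a higher number a weaker inhibitor:
compound 1 `CCCCCCC(CCO)n1cnc2c(Cl)ncnc21` gives 11900 nM.
compound 2 `CCCCCCC(CCO)n1cnc2cncnc21` reaches only the limit of > 50000 nM.
compound 3 `CCCCCCCC(CCO)n1cnc2c(N)ncnc21` reaches only the limit of > 50000 nM.

The one counted step among these is chloro in place of hydrogen on an aromatic carbon; it yields an at least 4.2-fold lower number from compound 2 to compound 1 (0.62 log units; beyond the scatter), the single measured gain in the series. The difference between the cores of compound 2 and compound 3 is not broken down here.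

Compound 4 `CCCCCCCC(CCO)n1cnc2c(N)nc(Cl)nc21` is not yet measured. It differs from compound 3 by chloro in place of hydrogen on an aromatic carbon. This is the same kind of change as that from compound 2 to compound 1, but not the same: in compound 1 the chloro sits next to the ring nitrogen, ortho to a fused ring, meta to a fused ring and opposite the ring nitrogen, whereas in compound 4 it sits between two ring nitrogen atoms, meta to a fused ring, meta to an amino group and para to a fused ring.

In this assay the expected step is an at least 2.5-fold lower number from compound 3 to compound 4 (0.39 log units; beyond the scatter), modest, resting on the earlier at least 4.2-fold lower number from compound 2 to compound 1 (0.62 log units; beyond the scatter). The start is poorly fixed because compound 3 sits at the limit of > 50000 nM in this assay, at which 2 of the 3 values shown sit. Compound 4 is estimated at 20000 nM, expected between 6000 nM and 60000 nM.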

Compound 4, half-maximal inhibitory concentration: > 50000 nM
Compound 4: only a limit was reported; the forecaster's own chance of this, stated with the estimate: 35%; at least 2.5-fold (0.39 log units) between middle value and limit.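

Compound 3 and compound 4 both stand only as limits in this assay, so no step can be read between them: the limit of > 50000 nM in this assay, at which 3 of the 4 values shown sit.

The compounds shown leave open whether chloro in place of hydrogen on an aromatic carbon changes the number at all on the core of compound 3.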